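Carbamate series at the urotensin receptor: the next analogue

The source may hold more compounds than are shown below. What is called first, only, known or untested is meant among the compounds shown, and "the series" means these compounds.

Values in an assay on NIH3T3 cells with Urotensin-2 receptor (Homo sapiens) as the target; a higher number here means that more compound is needed for the effect, a lower number that less compound is needed:
compound 1 `CCc1ccccc1C(=O)OC(CCN(C)C)c1ccc(Cl)cc1`: 1290 nM
compound 2 `COc1ccc(NC(=O)OC(CCN(C)C)c2ccc(Cl)cc2)cc1`: 1660 nM
compound 3 `CN(C)CCC(OC(=O)Nc1ccc(C(F)(F)F)cc1)c1ccc(Cl)cc1`: 251 nM

Compound 3 holds the lowest number of the three; compound 1 and compound 2 both sit above it by margins beyond the scatter, so compound 3 is the strongest of the measured set in this assay.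

Compound 4 `CN(C)CCC(OC(=O)Nc1ccc(Oc2ccccc2)cc1)c1ccc(Cl)cc1` is not yet measured. It differs from compound 3 by phenoxy in place of trifluoromethyl on an aromatic carbon. Among the compounds with values here, the only measured step at this position is a 6.6-fold lower number from compound 2 to compound 3 (0.82 log units; beyond the scatter), where a methoxy was exchanged for trifluoromethyl. Phenoxy shares the ether oxygen with methoxy but brings a further aromatic ring, and no measured compound carries an aryl ether, so that step gives direction only loosely. A return toward the level of compound 2 is plausible, though the added ring may be tolerated; a modest rise is expected.

Compound 4 is therefore estimated at 450 nM, with a range from 120 nM to 1700 nM, an expected step of a 1.8-fold higher number from compound 3 to compound 4 (0.25 log units; within the scatter) in this assay.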

Compound 4, half-maximal effective concentration: 191 nM
The estimate for compound 4 lay 2.4-fold (0.37 log units) above the measured number, and the stated range covers the measured number.
By their numbers in this assay, from the lowest: compounds 4 and 3 (each within the scatter of the next); then compounds 1 and 2 (each within the scatter of the next).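

In this assay, phenoxy in place of trifluoromethyl on an aromatic carbon, para to a large group, gives a 1.3-fold lower number from compound 3 to compound 4 (0.12 log units; within the scatter), so at this position a group with a further aromatic ring reads the same as trifluoromethyl within the scatter. The ether oxygen alone does not set the number: phenyl in place of methyl on that oxygen gives an 8.7-fold lower number from compound 2 to compound 4 (0.94 log units; beyond the scatter), which separates the two ethers beyond the scatter and shows that the level of compound 2 does not hold for every ether at this position. No measurement at hand explains either step.

Still open, going by these compounds, is how a carboxylic acid or an amine would read in this place. On these data alone, a chloro or nitrile on the added phenyl ring of compound 4 is equally open.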